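The source may report more compounds than this note shows. Statements on the series, on what has been measured and on what is new or still open speak of the compounds shown alone.

In an assay on isolated protein for displacement of a labelled ligand from melanin-concentrating hormone receptor 1 (Homo sapiens) (a lower number here means a stronger inhibitor, a higher number a weaker inhibitor), compound 1 `CCCc1cc(N)c2cc(NC(=O)CCc3ccccc3)ccc2n1` gives 8300 nM, compound 2 `CCCc1cc(N)c2cc(NC(=O)/C=C/c3ccc(F)cc3)ccc2n1` gives 130 nM, and compound 3 `Nc1cc(C2CCCCC2)nc2ccc(NC(=O)/C=C/c3ccc(C(F)(F)F)cc3)cc12` gives 1.2 nM. Compound 2 thus stands second highest of the three, well apart from both neighbours. Compound 4 `CCCc1cc(N)c2cc(NC(=O)/C=C/c3ccc(I)cc3)ccc2n1` differs from compound 2 only by iodo in place of fluoro on an aromatic carbon, on an aromatic carbon of a six-membered aromatic ring of carbon only, para to a large group. Among the measured compounds shown here, no measured pair shows this exact exchange, so no step for it is known; compound 3, with a different group at that place and another change elsewhere, sits far lower. The step from compound 2 to compound 4 is expected to be a modest move toward lower numbers, about a 2.6-fold lower number from compound 2 to compound 4 (0.41 log units; beyond the scatter). For compound 4 the expected value in this assay is 50 nM, with a range from 15 nM to 200 nM.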

Compound 4, half-maximal inhibitory concentration: 2.3 nM
Beside the measured number, compound 4's estimate is 22-fold (1.34 log units) above it; the whole stated range lies above it.
By their numbers in this assay, from the lowest: compounds 3 and 4 (each within the scatter of the next); then compound 2; then compound 1.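

In this assay, replacing a single fluoro with iodo on the aromatic carbon para to a large group gives a 57-fold lower number from compound 2 to compound 4 (1.75 log units; beyond the scatter). The earlier compounds shown here could not show this, since none of them differed in one place only; it shows that the number is highly sensitive to the atom held at this position. Nothing available here explains the size of this step.

Going by these compounds, whether chloro or bromo at this place would give a number between those of compound 2 and compound 4 remains open. So does how a methoxy group or an amine there would compare.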